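The compounds below may be only part of what the source reports. "The series", "measured", "known", "first", "only" and "open" are said of these compounds alone.

In a functional assay on SW-620 cells (Homo sapiens) for cytotoxicity (a lower number here means a stronger inhibitor, a higher number a weaker inhibitor), compound 1 `O=C(CCCCCCC(=O)Nc1nc2ccccc2s1)NO` gives 4.01 ug/mL and compound 2 `CCOc1ccc2nc(NC(=O)CCCCC(=O)NO)sc2c1` gives 9.26 ug/mL as the half-maximal inhibitory concentration. Compound 2 therefore stands at the higher of the two numbers, and the gap lies beyond the usual scatter. Compound 3 `CCOc1ccc2nc(NC(=O)CCCCCCC(=O)NO)sc2c1` differs from compound 2 by 2-(hydroxycarbamoyl)ethyl in place of hydroxycarbamoyl on a saturated chain carbon, four bonds along the chain from a carbonyl carbon and the change reads as 2-(hydroxycarbamoyl)ethyl in place of hydroxycarbamoyl on a saturated chain carbon, four bonds along the chain from a carbonyl carbon. Among the compounds with values here, no measured pair differs in one place only, so the data give no direct size for this change in this assay and the expectation remains tentative. Within the data shown here, a moderate move to a lower number is expected, with compound 1 at 4.01 ug/mL as the only lower value in hand. The estimated step is a 2.2-fold lower number from compound 2 to compound 3 (0.34 log units; beyond the scatter) and it points to a lower number. The estimate for compound 3 is 4.2 ug/mL with 1.4 ug/mL to 12 ug/mL as the expected range.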

Compound 3, half-maximal inhibitory concentration: 10.4 ug/mL
The estimate for compound 3 lay 2.5-fold (0.39 log units) below the measured number; the range from low to high includes it.
By their numbers in this assay, from the lowest: compound 1; then compounds 2 and 3 (each within the scatter of the next).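

In this assay, 2-(hydroxycarbamoyl)ethyl in place of hydroxycarbamoyl on a saturated chain carbon, four bonds along the chain from a carbonyl carbon, gives a 1.1-fold higher number from compound 2 to compound 3 (0.05 log units; within the scatter), so at this position and with the ethoxy group present, the two chains cannot be told apart in this read-out. With the chain of compound 3 held fixed, ethoxy in place of hydrogen on an aromatic carbon gives a 2.6-fold higher number from compound 1 to compound 3 (0.41 log units; beyond the scatter), a modest step and the only one here that clears the scatter. Nothing available bears on the reason for either step.

As far as these compounds go, whether the chain change reads the same on the core of compound 1, without the ethoxy group, remains open. Also open, from the compounds shown here alone, are a longer chain at this position and a methoxy group or a chlorine atom in place of the ethoxy group.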